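Aminophenyl series: removing the sulfonamide arm

The compounds below may be only part of what the source reports. "The series", "measured", "known", "first", "only" and "open" are said of these compounds alone.

Measured compounds:
compound 1 `Nc1cc(-c2cnc3[nH]cc(-c4ccncc4)c3c2)ccc1Cl`: 53.7 nM
compound 2 `CC(=O)Nc1cccc(-c2cnc3[nH]cc(-c4ccncc4)c3c2)c1`: 34.3 nM
compound 3 `Nc1cc(NS(=O)(=O)c2ccccc2)cc(-c2cnc3[nH]cc(-c4ccncc4)c3c2)c1`: 9.4 nM

In an assay on isolated protein for inhibition of high affinity nerve growth factor receptor (Homo sapiens), read by 33P incorporation (on this read-out higher numbers stand for weaker inhibition and lower numbers for stronger inhibition), compound 3 gives 9.4 nM, the lowest number of the three. Compound 2 gives 34.3 nM and compound 1 gives 53.7 nM; both gaps to compound 3 are beyond the scatter, so compound 3 stands as the strongest inhibitor among the measured set.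

Compound 4 `Nc1cccc(-c2cnc3[nH]cc(-c4ccncc4)c3c2)c1` is the unmeasured analogue. The change from compound 3 is hydrogen in place of (phenylsulfonyl)amino on an aromatic carbon. Among the measured compounds shown here, no pair of measured compounds differs in a single place, so there is no measured step to lean on; the expectation rests on where the bare aminophenyl analogues sit.

The step from compound 3 to compound 4 is expected to raise the number beyond the scatter, estimated at a 4.3-fold higher number from compound 3 to compound 4 (0.63 log units; beyond the scatter), because compound 1 gives 53.7 nM and compound 2 gives 34.3 nM. Compound 4 is accordingly expected to give about 40 nM in this assay, within a range of 15 nM to 120 nM.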

Compound 4, half-maximal inhibitory concentration: 42.7 nM
The estimate for compound 4 lay 1.1-fold (0.03 log units) below the measured number; low and high end bracket the measured number.
By their numbers in this assay, from the lowest: compound 3; then compounds 2, 4 and 1 (each within the scatter of the next).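

In this assay, the (phenylsulfonyl)amino group on this aromatic carbon carries a real part of the inhibition, since replacing it with hydrogen gives a step beyond the scatter (a 4.5-fold higher number from compound 3 to compound 4 (0.66 log units; beyond the scatter)). The two other changes to compound 4 stay within the scatter: hydrogen in place of acetyl on a nitrogen on an aromatic ring (a 1.2-fold higher number from compound 2 to compound 4 (0.10 log units; within the scatter)) and hydrogen in place of chloro on an aromatic carbon (a 1.3-fold lower number from compound 1 to compound 4 (0.10 log units; within the scatter)). So among these compounds, only the (phenylsulfonyl)amino change shifts the number beyond the scatter, and nothing available explains why.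

Open, going by these compounds, is whether the phenyl ring or the sulfonyl link is what counts at this position. Methylsulfonylamino or benzoylamino on the same carbon would separate the two.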